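Shortening the Acid Arm: From Compound 1 to Compound 3

This account rests on a few compounds, and the source may have more. Where it says the series, first, only, none or still open, it means among the compounds named here.

Compound 1 `O=C(O)CNc1cccc(CNc2cc(C(F)(F)F)cc3[nH]ncc23)c1` gives no number in an assay for inhibition of Tryptophan 2,3-dioxygenase (Homo sapiens), with stated times of 10 min and 60 min (on this read-out lower numbers stand for stronger inhibition and higher numbers for weaker inhibition), but only a limit: for compound 1 the value > 100000 nM is the limit of this assay. This is where compound 1 stands: the limit of > 100000 nM in this assay, at which 1 of the 2 values shown sits. Compound 2 `O=[N+]([O-])c1ccc(CNc2cc(Br)cc3[nH]ncc23)cc1` gives 2230 nM in this assay. Compound 3 `O=C(O)c1cccc(CNc2cc(C(F)(F)F)cc3[nH]ncc23)c1` differs from compound 1 by carboxy in place of (carboxymethyl)amino on an aromatic carbon. Within the data shown here, no measured pair shows this change. The step from compound 1 to compound 3 is expected to be an at least 1.6-fold lower number from compound 1 to compound 3 (0.22 log units; that floor lies within the scatter), toward stronger inhibition, though it may stay within the scatter. Compound 3 is estimated at 60000 nM, between 8000 nM and 200000 nM.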

Compound 3, half-maximal inhibitory concentration: 1690 nM
For compound 3 the middle estimate is 36-fold (1.55 log units) above the measured one; the measured number lies below the stated range.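

Putting carboxy in place of (carboxymethyl)amino on this aromatic carbon gives an at least 59-fold lower number from compound 1 to compound 3 (1.77 log units; beyond the scatter) in this assay. An acid group at this place can therefore go with a measurable value, which compound 1 alone could not show. The step is a floor and not an exact size, because compound 1 stands at a limit of the assay: the limit of > 100000 nM in this assay, at which 1 of the 3 values shown sits. Still open, on these data alone, is how an amine alone, or a carboxylic acid on a longer chain, would read at this place. Compound 2 differs from compound 3 in more than one place, so it cannot settle this.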